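A few compounds are considered here, and "the series" means these few. Any claim that something is new, unique, unknown or untested is made for them only; others in the source may bear on it.

Measured in a functional assay on HEY cells (Homo sapiens) for cytotoxicity, read by MTT assay, with a stated time of 72 h; a higher number here means a weaker inhibitor, a lower number a stronger inhibitor:

- Compound 1 `N[C@H]1CC[C@H](Nc2c(C(=O)NCc3ccc(F)cc3)nc(Br)c3cccnc23)CC1`: "not determined" (no result reported)
- Compound 2 `COc1ccc(CNC(=O)c2nc(Br)c3cccnc3c2N[C@H]2CC[C@H](N)CC2)cc1`: 4000 nM
- Compound 3 `N[C@H]1CC[C@H](Nc2c(C(=O)NCc3ccc(Cl)cc3Cl)nc(Br)c3cccnc23)CC1`: 5000 nM

Compound 1 offers no comparison, so compound 3 can be set only against compound 2, and the two cannot be told apart. Going by the values given here, the single measured step, a 1.3-fold higher number from compound 2 to compound 3 (0.10 log units; within the scatter), lies within the scatter.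

Compound 4 `COC(=O)c1nc(Br)c2cccnc2c1N[C@H]1CC[C@H](N)CC1` keeps the shared core but alters the group on the carbonyl carbon: methoxy in place of (2,4-dichlorobenzyl)amino on a carbonyl carbon. The measured step bears on this only loosely. It exchanges what the aromatic ring carries, while the ring itself stays in both compounds. Among the compounds with values here, in compound 4 the whole (2,4-dichlorobenzyl)amino leaves, and no measured step covers a change of that kind.

The flat step gives no ground for expecting a large move, yet it cannot rule one out. A modest shift towards a higher number in this assay is therefore expected, as a judgement held with little confidence. The expected change is a 2.4-fold higher number from compound 3 to compound 4 (0.38 log units; beyond the scatter). For compound 4 the estimate is 12000 nM, with an expected range of 3000 nM to 40000 nM.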

Compound 4, half-maximal inhibitory concentration: > 20000 nM
Compound 4 ended at the assay's limit; the forecaster's own chance of this, stated with the estimate: 30%; middle value at least 1.6-fold (0.22 log units) away from the limit.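

In this assay compound 4 gives > 20000 nM, which is a limit of the assay and not a number: the limit of > 20000 nM in this assay, at which 1 of the 4 values shown sits.

The earlier step changed only what the aromatic ring carries and stayed within the scatter, whereas replacing the whole group on the carbonyl carbon moves the result beyond it. Methoxy in place of (2,4-dichlorobenzyl)amino gives an at least 4.0-fold higher number from compound 3 to compound 4 (0.60 log units; beyond the scatter), and methoxy in place of (4-methoxybenzyl)amino gives an at least 5.0-fold higher number from compound 2 to compound 4 (0.69 log units; beyond the scatter). The position on the carbonyl carbon therefore responds to this exchange in both comparisons, with two differently substituted benzyl amides each giving a lower number than the methyl ester of compound 4, a contrast the earlier pair could not show.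

The change removes the aromatic ring and the amide hydrogen together, so the compounds shown do not say which of the two matters, and a plain methylamino group or a longer chain ending in an amine on the carbonyl carbon could begin to separate them. Going by these compounds, how far compound 4 truly lies from compounds 2 and 3 also stays open, since its result marks only a limit.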